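The source may hold more compounds than are shown below. What is called first, only, known or untested is meant among the compounds shown, and "the series" means these compounds.

In a functional assay on HUVEC cells (Homo sapiens) (on this read-out higher numbers stand for an effect only at larger amounts of compound and lower numbers for an effect already at smaller amounts), compound 1 `Cc1c(O)c(C)c2c(c1O)C(=O)CC(c1cccc(O)c1)O2` gives > 20000 nM, which is a limit of the assay and not a number. In this assay compound 2 `Cc1c(O)c(C)c2c(c1O)C(=O)CC(c1ccccc1[N+](=O)[O-])O2`, built on the same shared core, gives > 5000 nM, which is also a limit. Going by the values given here, compound 1 therefore has no exact position on the numbers so far, and the two limits cannot be ranked against each other.

Compound 3 `Cc1c(O)c(C)c2c(c1O)C(=O)CC(c1ccsc1)O2` keeps the core of compound 1 but carries thiophen-3-yl in place of 3-hydroxyphenyl on a saturated ring carbon. Among the compounds with values here, no measured pair shows what such a swap does, so only a modest change in this assay is expected, more likely towards lower numbers, and another limit would be no surprise. The estimated step is an at least 1.6-fold lower number from compound 1 to compound 3 (0.22 log units; that floor lies within the scatter). For compound 3 the expected value is 12000 nM, with an estimated range from 3000 nM to 40000 nM.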

Compound 3, half-maximal effective concentration: > 50000 nM
Compound 3: a limit, no number; the forecaster's own chance of this, stated with the estimate: 65%; middle value at least 4.1-fold (0.61 log units) from the limit.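

Compound 1 and compound 3 both give only a limit in this assay, not a number, so no step can be read between them. The compounds shown leave open how far thiophen-3-yl in place of 3-hydroxyphenyl shifts the read-out, or in which direction.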